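A few compounds are considered here, and "the series" means these few. Any claim that something is new, unique, unknown or untested is made for them only; others in the source may bear on it.

Measured compounds:
- compound 1 `COc1cccc2sc(NC(=O)c3ccc(C(F)(F)F)cc3)nc12`: > 10 ug/mL
- compound 2 `COc1cccc2sc(NC(=O)c3ccc(C#N)cc3)nc12`: > 10 ug/mL
- compound 3 `COc1ccc2sc(NC(=O)c3ccc(C(F)(F)F)cc3)nc2c1`: > 10 ug/mL

All three compounds were tested in a functional assay on MDA-MB-231 cells (Homo sapiens) for antiproliferative activity, read by sulforhodamine B assay; on this read-out higher numbers stand for weaker inhibition of growth and lower numbers for stronger inhibition of growth. In this assay compound 1 gives > 10 ug/mL, which is a limit of the assay and not a number. Compound 2 likewise gives > 10 ug/mL, again a limit. Compound 3 gives > 10 ug/mL, also a limit. The three values thus share one feature: the limit of > 10 ug/mL in this assay, at which 3 of the 3 values shown sit.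

Compound 1 and compound 2 share a core and differ by cyano in place of trifluoromethyl on an aromatic carbon. The matching step, a step that the two limits leave unreadable from compound 1 to compound 2, cannot be sized, as both ends are limits. Compound 1 and compound 3 have the same atoms joined differently; the difference between the two cores is not broken down here.

Compound 4 `COc1ccc2sc(NC(=O)c3ccc(C#N)cc3)nc2c1` has not yet been measured in this assay. It differs from compound 3 by cyano in place of trifluoromethyl on an aromatic carbon, which is the same change as that from compound 1 to compound 2, with the place described in identical words. Compound 3 sits at a limit with > 10 ug/mL. Among the measured compounds shown here, the only precedent for this change is the unreadable step that the two limits leave unreadable from compound 1 to compound 2, so there is no measured basis for a shift in either direction, and the step that the limit leaves unreadable from compound 3 to compound 4 is expected to be small. Compound 4 is expected to give about 15 ug/mL, most plausibly between 8 ug/mL and 40 ug/mL, and it is likely that this assay again returns only a limit.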

Compound 4, concentration for 50% growth inhibition: > 10 ug/mL
Compound 4: a limit, no number; the forecaster's own chance of this, stated with the estimate: 85%; the middle value lies beyond the limit too.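

In this assay compound 4 gives > 10 ug/mL, which is a limit and not a number, so the step from compound 3 to compound 4 cannot be read. The four compounds share one result: the limit of > 10 ug/mL in this assay, at which 4 of the 4 values shown sit.

The compounds shown leave open how far each lies past that limit, and whether cyano in place of trifluoromethyl, or the difference between the two cores, alters growth inhibition at all.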